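From piperazin-1-yl to an open chain

This account rests on a few compounds, and the source may have more. Where it says the series, first, only, none or still open, it means among the compounds named here.

Of the compounds shown here, two sharing one core have been measured so far in a functional assay on MCF7 cells (Homo sapiens) for cytotoxicity, read by MTT assay, with a stated time of 72 h; on this read-out lower numbers stand for stronger inhibition and higher numbers for weaker inhibition. Compound 1 (`O=C(NCCCNc1c(C(=O)NCc2ccc(F)cc2)nc(Br)c2cccnc12)c1ccccc1`) gives 2000 nM. Compound 2 (`O=C(NCc1ccc(F)cc1)c1nc(Br)c2cccnc2c1N1CCNCC1`) gives 7000 nM, the higher of the two numbers and therefore the weaker result, with a gap beyond the usual scatter.

The next molecule, compound 3 (`CNCCCNc1c(C(=O)NCc2ccc(F)cc2)nc(Br)c2cccnc12`), has not been measured yet. It keeps the rest of compound 2 but carries (3-(methylamino)propyl)amino in place of piperazin-1-yl on an aromatic carbon, para to a bromo group: (3-(methylamino)propyl)amino in place of piperazin-1-yl on an aromatic carbon. A ring thus gives way to an open chain.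

Among the compounds with values here, no measured pair isolates this change, so the evidence is thin. Within the data shown here, the one hint is that compound 1, which also carries an open chain on that carbon, reads 2000 nM. A modest gain in inhibition is therefore expected, close to the edge of the scatter: the estimated change is a 2.3-fold lower number from compound 2 to compound 3 (0.37 log units; beyond the scatter). In this assay the estimated value for compound 3 is 3000 nM, with an expected range from 1000 nM to 9000 nM.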

Compound 3, half-maximal inhibitory concentration: > 10000 nM
Compound 3: no number, only a limit (the forecaster's own chance of this, stated with the estimate: 5%); middle value at least 3.3-fold (0.52 log units) from the limit.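

Compound 3 reaches no exact number in this assay, only a limit of the assay: the limit of > 10000 nM in this assay, at which 1 of the 3 values shown sits.

Replacing the ring with the open chain gives an at least 1.4-fold higher number from compound 2 to compound 3 (0.15 log units; that floor lies within the scatter) and thus shows no gain from (3-(methylamino)propyl)amino over piperazin-1-yl on this aromatic carbon, although whether there is a real loss stays unsettled. The comparison with compound 1 is clearer: methyl in place of benzoyl on the amine nitrogen gives an at least 5.0-fold higher number from compound 1 to compound 3 (0.69 log units; beyond the scatter) and shows that, on this open chain, the group at the far end matters. The better reading of compound 1 therefore cannot be credited to an open chain as such, only to the chain with its benzoyl group.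

On these data alone, what remains open is which part of the benzoyl group matters, a question that an acetyl group or a benzyl group on the same nitrogen could help answer. Also open, as far as these compounds go, are whether a shorter two-carbon chain would keep the reading of compound 1, and whether a benzoyl group on the free nitrogen of the piperazine ring would bring a similar shift to compound 2.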